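Propoxy to butoxy on the shared core: working notes

A few compounds are considered here, and "the series" means these few. Any claim that something is new, unique, unknown or untested is made for them only; others in the source may bear on it.

Measured compounds:
compound 1 `CCCOc1cc(NC(=O)NNc2cc(-c3ccc(OC)cc3)c3cnn(C)c3n2)cc(Cl)n1` — 37200 nM
compound 2 `CCCc1cc(NNC(=O)Nc2cc(Cl)nc(Cl)c2)nc2c1c(C)nn2C` — 40800 nM

In a functional assay on SW620/5-FU cells (Homo sapiens) for cytotoxicity, read by MTT assay, with a stated time of 48 h, in the presence of a further agent that is not named here (on this read-out lower numbers stand for an effect already at smaller amounts and higher numbers for an effect only at larger amounts of compound), compound 1 gives 37200 nM, the lowest of the two numbers recorded. The nearest number is that of compound 2, which in this assay gives 40800 nM; the two values lie within the scatter of each other, so nothing separates compound 1 from compound 2 on this read-out. Going by the values given here, both numbers sit in the weak range, and no step between measured compounds is available to calibrate any structural change.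

Compound 3 `CCCCOc1cc(NC(=O)NNc2cc(-c3ccc(OC)cc3)c3cnn(C)c3n2)cc(Cl)n1` is the next compound to be measured in this assay. It differs from compound 1 by methyl in place of hydrogen on a saturated chain carbon, three bonds along the chain from an oxygen on an aromatic ring. Among the compounds with values here, with no measured step of the same kind to lean on, the expectation for such a chain extension is a step that stays within the scatter, in either direction or in none. Compound 3 is therefore expected to give about 32000 nM, with a range from 13000 nM to 80000 nM. The step this estimate implies is a 1.2-fold lower number from compound 1 to compound 3 (0.07 log units; within the scatter), which is expected to fall within the usual scatter.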

Compound 3, half-maximal effective concentration: 39200 nM
Compound 3: the middle estimate sits 1.2-fold (0.09 log units) below what was measured; low and high end bracket the measured number.
By their numbers in this assay, from the lowest: compounds 1, 3 and 2 (each within the scatter of the next).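

In this assay, going by these compounds alone, the step at this position reads a 1.1-fold higher number from compound 1 to compound 3 (0.02 log units; within the scatter) and is the only step between compounds that differ in one place, which compound 1 and compound 2 could not provide. It shows that methyl in place of hydrogen on a saturated chain carbon, three bonds along the chain from an oxygen on an aromatic ring, which here takes propyl to butyl, leaves the number unchanged within the scatter, and this holds for this one pair only. No measurement bears on what lies behind this result.

Still open, from the compounds shown here alone, is whether a longer chain such as hexyl, or an amine or a carboxylic acid at the end of the chain, would carry the number beyond the scatter, or whether this position stays as unresponsive as the propyl to butyl change suggests. Also open, going by these compounds, is whether the same change would read the same way on a core with other groups, as a single step on the shared core of compound 1 cannot answer that.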